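The source may hold more compounds than are shown below. What is called first, only, known or untested is meant among the compounds shown, and "the series" means these compounds.

In a functional assay on KB cells (Homo sapiens) for cytotoxicity (a higher number here means a weaker inhibitor, a lower number a stronger inhibitor), compound 1 (`CCCOC1=CC(=O)c2ccccc2C1=O`) gives 49400 nM and compound 2 (`C/C=C/C(=O)OC1=CC(=O)c2ccccc2C1=O`) gives 64200 nM, while compound 3 (`CS(=O)(=O)OC1=CC(=O)c2ccccc2C1=O`) gives 7180 nM as the lowest of the three numbers. Compound 4 (`O=C1C=C(Oc2ccco2)C(=O)c2ccccc21`) has furan-2-yl in place of methylsulfonyl on an oxygen on an unsaturated carbon. Compounds 1 and 2 lie within the scatter of each other (a 1.3-fold higher number from compound 1 to compound 2 (0.11 log units; within the scatter)), whereas the steps to methylsulfonyl were modest (a 6.9-fold lower number from compound 1 to compound 3 (0.84 log units; beyond the scatter) and an 8.9-fold lower number from compound 2 to compound 3 (0.95 log units; beyond the scatter)). Going by the values given here, no measured step tests furan-2-yl, so the expectation rests on those steps, with compound 3 alone carrying methylsulfonyl. A modest rise in this assay is therefore expected. The estimated change is a 4.2-fold higher number from compound 3 to compound 4 (0.62 log units; beyond the scatter) in size. Compound 4 is expected at 30000 nM with an estimated range of 9000 nM to 90000 nM here.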

Compound 4, half-maximal inhibitory concentration: 53400 nM
Estimate against measurement, compound 4: 1.8-fold (0.25 log units) below; measured number inside the range.
By their numbers in this assay, from the lowest: compound 3; then compounds 1, 4 and 2 (each within the scatter of the next).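

In this assay, furan-2-yl on this oxygen does not keep the lower number seen with methylsulfonyl, giving a 7.4-fold higher number from compound 3 to compound 4 (0.87 log units; beyond the scatter). It also cannot be told apart from the other two groups, with a 1.1-fold higher number from compound 1 to compound 4 (0.03 log units; within the scatter) and a 1.2-fold lower number from compound 2 to compound 4 (0.08 log units; within the scatter), so three different groups sit together and only compound 3 stands apart from them. Nothing available explains this difference. As far as these compounds go, whether the lower number belongs to methylsulfonyl alone or to sulfonyl groups more widely remains open. So does what an amine or a phenylsulfonyl group would give at this place.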